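Changing the group on the carbonyl of compound 2

The source may hold more compounds than are shown below. What is called first, only, known or untested is meant among the compounds shown, and "the series" means these compounds.

Measured values in a functional assay on MIA PaCa-2 cells (Homo sapiens) for antiproliferative activity, read by sulforhodamine B assay, with a stated time of 48 h (a lower number here means a stronger inhibitor, a higher number a weaker inhibitor), are as follows
compound 1 `COc1cc(OC)c2sc(-c3ccc(N/C=C\C(=O)c4ccc(OC)c(O)c4)c(C)c3)nc2c1` gives 22100 nM
compound 2 `COc1cc(OC)c2sc(-c3ccc(N/C=C\C(=O)c4ccc(OC)c(O)c4)cc3)nc2c1` gives 11600 nM
compound 3 `COc1ccc(C(=O)/C=C\Nc2ccc(-c3nc4cc(OC)c(OC)c(OC)c4s3)cc2)cc1O` gives 32800 nM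

Compound 2 cannot be told apart from compound 1, since a 1.9-fold lower number from compound 1 to compound 2 (0.28 log units; within the scatter) stays within the scatter. Against compound 3 it does stand apart, as a 2.8-fold higher number from compound 2 to compound 3 (0.45 log units; beyond the scatter) is a modest step beyond the scatter.

For the measured compounds named here, compound 4 `COc1cc(OC)c2sc(-c3ccc(N/C=C\C(=O)c4cc(OC)c(OC)c(OC)c4)cc3)nc2c1` has no measurement yet. The change that sets it apart from compound 2 is this one 3,4,5-trimethoxyphenyl in place of 3-hydroxy-4-methoxyphenyl on a carbonyl carbon and it sits on a carbonyl carbon. Neither measured step touches that group, so both offer only loose guidance. The closest hint is the added methoxy in a 2.8-fold higher number from compound 2 to compound 3 (0.45 log units; beyond the scatter) which points weakly toward a higher number. In this assay the expected change is a 1.3-fold higher number from compound 2 to compound 4 (0.11 log units; within the scatter) and so a small rise, probably not beyond the scatter. For compound 4 the estimated value is 15000 nM with an expected range from 5000 nM to 45000 nM in all.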

Compound 4, half-maximal inhibitory concentration: 26800 nM
The estimate for compound 4 lay 1.8-fold (0.25 log units) below the measured number, within the range that was stated.
By their numbers in this assay, from the lowest: compounds 2, 1, 4 and 3 (each within the scatter of the next, the first and the last beyond it).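

This is the first change shown at the group on the carbonyl carbon, as the earlier steps altered other parts of the molecule. In this assay, 3,4,5-trimethoxyphenyl in place of 3-hydroxy-4-methoxyphenyl gives a 2.3-fold higher number from compound 2 to compound 4 (0.36 log units; beyond the scatter), a modest step beyond the scatter, so this position does respond to a change of group. The swap loses the 1 hydrogen-bond donor of the leaving group and adds heavy atoms, yet the entering group brings no lower number than compound 2 shows. No data shown here explain why the number rises.

Compound 4 differs from compound 2 in two ways on this ring, so the share of the missing hydroxy and that of the extra methoxy cannot be separated. As far as these compounds go, whether an amine in place of the hydroxy, as in 3-amino-4-methoxyphenyl, would keep or lower the number also stays open.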